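The compounds below may be only part of what the source reports. "The series", "measured", "known", "first", "only" and "open" are said of these compounds alone.

Measured in an ADME assay on HepG2 cells (Homo sapiens) for cytotoxicity, read by luminescence, CellTiter-Glo and ATP content, with a stated time of 72 h; on this read-out higher numbers stand for an effect only at larger amounts of compound and lower numbers for an effect already at smaller amounts:
- compound 1 `COc1cccc(CNCCCNc2ccnc3cc(Oc4ccc(F)cc4)ccc23)c1O`: 11000 nM
- compound 2 `COc1cccc(CNCCCNc2ccnc3cc(Cc4ccc(C#N)cc4)ccc23)c1O`: 7150 nM
- compound 3 `COc1ccc(-c2ccc3c(NCCCNCc4cccc(OC)c4O)ccnc3c2)cc1`: 1600 nM

Compound 3 gives the lowest number of the three: a 4.5-fold lower number from compound 2 to compound 3 (0.65 log units; beyond the scatter) and a 6.9-fold lower number from compound 1 to compound 3 (0.84 log units; beyond the scatter), both beyond the scatter, while a 1.5-fold lower number from compound 1 to compound 2 (0.19 log units; within the scatter) stays within it.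

Compound 4 `COc1cccc(CNCCCNc2ccnc3cc(C4CCCCC4)ccc23)c1O` differs from compound 3 in one place: cyclohexyl in place of 4-methoxyphenyl on an aromatic carbon. Among the measured compounds shown here, no measured step swaps an aromatic ring for a non-aromatic one, so the bearing steps are only indirect. Compound 3 stands apart from compounds 1 and 2 by modest steps, and compound 4 lacks the 4-methoxyphenyl that marks compound 3. A higher number, toward compounds 1 and 2, is expected: a 2.5-fold higher number from compound 3 to compound 4 (0.40 log units; beyond the scatter). Compound 4 is estimated at 4000 nM, range 1500 nM to 12000 nM.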

Compound 4, half-maximal effective concentration: 1080 nM
Compound 4: middle estimate off by 3.7-fold (0.57 log units), on the high side; the measured number lies below the stated range.
By their numbers in this assay, from the lowest: compounds 4 and 3 (each within the scatter of the next); then compounds 2 and 1 (each within the scatter of the next).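

Replacing the aromatic ring at this position with a non-aromatic one leaves the number in place, a 1.5-fold lower number from compound 3 to compound 4 (0.17 log units; within the scatter), so among these compounds a low number does not depend on 4-methoxyphenyl or on an aromatic ring here. Cyclohexyl stands well apart from the other two groups, a 6.6-fold lower number from compound 2 to compound 4 (0.82 log units; beyond the scatter) and a 10-fold lower number from compound 1 to compound 4 (1.01 log units; beyond the scatter), which puts compounds 3 and 4 together as one low pair against compounds 1 and 2, with no compound going against this split. Nothing measured here explains the split.

Still open, on these data alone, is whether a piperidine ring, with its amine, or a cyclohexyl bearing a carboxylic acid would stay with compounds 3 and 4 or move toward compounds 1 and 2.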